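The source may report more compounds than this note shows. Statements on the series, on what has been measured and on what is new or still open speak of the compounds shown alone.

Measured compounds:
compound 1 `Nc1nc(N2CCN(C3CCCC3)CC2)c2ncn(CCCN3CCCC3)c2n1` gives 120 nM in an assay on HEK293 cells for antagonist activity at Toll-like receptor 9 (Homo sapiens), read by spectrophotometry; a lower number here means a stronger inhibitor, a higher number a weaker inhibitor
compound 2 `CCN1CCN(CCCn2cnc3c(N4CCN(C(=O)C5CCCC5)CC4)nc(NCc4ccc(OC)cc4)nc32)CC1` gives the assay limit > 30000 nM in this assay
compound 3 `CCN1CCN(CCCn2cnc3c(N4CCN(CC)CC4)nc(N)nc32)CC1` gives 260 nM in this assay

Compound 1 holds the lowest of the two numbers that are actual numbers in this assay. Its nearest neighbour is compound 3, whose value sits a step beyond the usual scatter higher, so compound 1 reads as the stronger inhibitor of the two. Among the measured compounds shown here, compound 2 gives only a limit in this assay, and so cannot be placed relative to the other two; it is the one value that sits at the limit of > 30000 nM in this assay, at which 1 of the 3 values shown sits. For the measured compounds named here, no pair among the measured compounds differs in only one place, so no single structural step has been measured.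

The compound still to be measured is compound 4 `Fc1ccc(CNc2nc(N3CCN(C4CCCC4)CC3)c3ncn(CCCN4CCCC4)c3n2)cc1`. It differs from compound 1 as follows: 4-fluorobenzyl in place of hydrogen on a nitrogen on an aromatic ring. Compound 2 also carries a benzyl-type group on the same nitrogen, but it differs from compound 1 elsewhere too, so its limit shows nothing certain about this one change.

The step from compound 1 to compound 4 is expected to be a loss in this assay, of the size a 17-fold higher number from compound 1 to compound 4 (1.22 log units; beyond the scatter). Compound 4 is therefore estimated at 2000 nM, within a range from 300 nM to 15000 nM.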

Compound 4, half-maximal inhibitory concentration: 100 nM
Beside the measured number, compound 4's estimate is 20-fold (1.30 log units) above it; measured number below the stated range.
By their numbers in this assay, from the lowest: compounds 4 and 1 (each within the scatter of the next); then compound 3. At a limit, above all of these: compound 2.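

In this assay, the change from amino to (4-fluorobenzyl)amino gives a 1.2-fold lower number from compound 1 to compound 4 (0.08 log units; within the scatter). Among the compounds shown here, this is the first step measured at a single place, and it shows that this nitrogen on an aromatic ring accepts 4-fluorobenzyl, with 8 heavy atoms and one six-membered aromatic ring, in place of hydrogen without a change beyond the scatter, so the unsubstituted amino group is not required in this pair. Compound 2 also carries a benzyl-type group on this nitrogen but differs from compound 1 elsewhere too, and its value is only a limit of the assay, so the new step does not tie that limit to this nitrogen: the limit of > 30000 nM in this assay, at which 1 of the 4 values shown sits.

As far as these compounds go, whether the same holds for other groups on this nitrogen, such as unsubstituted benzyl, a 2-phenylethyl chain, a simple methyl or an acetyl, remains open. Also open is which of the differences between compound 1 and compound 2 accounts for the limit of compound 2, since no single-place step connects the two.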